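This account rests on a few compounds, and the source may have more. Where it says the series, first, only, none or still open, it means among the compounds named here.

Measured compounds:
- compound 1 `O=C(NS(=O)(=O)c1ccc(NC(=O)c2ccc(Cl)cc2Cl)cc1)c1ccccc1` — "not determined" (no result reported) in a functional assay on HEK293 cells for agonist activity at probable G-protein coupled receptor 27 (Homo sapiens), read by a luciferase reporter and beta-arrestin recruitment, with a stated time of 10 min; on this read-out higher numbers stand for larger maximal responses and lower numbers for smaller maximal responses
- compound 2 `O=C(Nc1ccc(S(=O)(=O)Nc2ncccn2)cc1)c1ccc(Cl)cc1Cl` — "not determined" (no result reported) in this assay
- compound 3 `O=C(Nc1ccc(S(=O)(=O)Nc2ccccc2Cl)cc1)c1ccc(Cl)cc1Cl` — 53%

Going by the values given here, compound 3 is the only member of the series with a number in this assay; compound 1 and compound 2 carry no result there, so no step between measured compounds can be drawn and no pattern is claimed. Compound 4 `Cc1ccccc1NS(=O)(=O)c1ccc(NC(=O)c2ccc(Cl)cc2Cl)cc1` differs from compound 3 by methyl in place of chloro on an aromatic carbon. On these data alone, with a single measured point, the size of this step is unknown; the expectation is a step of no size beyond the usual scatter, in either direction, a number 3 percentage points lower from compound 3 to compound 4 (within the scatter). Compound 4 is therefore estimated at 50%, with a range from 30% to 70%, resting only on the value of compound 3 and the small counted change.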

Compound 4, largest response reached (Emax), in percent of the reference or control that the assay uses: 32%
Compound 4: middle estimate off by 18 percentage points, on the high side; low and high end bracket the measured number.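

In this assay the series gets its first readable step, at the aromatic carbon ortho to a large group: methyl in place of chloro gives a number 21 percentage points lower from compound 3 to compound 4 (beyond the scatter) and shows that this position responds to a change of one heavy atom. Of this pair, the 2-chlorophenyl group carries the larger maximal response. No measured evidence bears on the origin of this step.

Steps to compound 1 and compound 2 cannot be read. Still open, on these data alone, is what fluoro, methoxy or an unsubstituted phenyl would give at this place.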